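Replacing 3,4-dihydroxyphenyl with 4-hydroxycyclohexyl on compound 2

This account rests on a few compounds, and the source may have more. Where it says the series, first, only, none or still open, it means among the compounds named here.

In a functional assay on RS4-11 cells (Homo sapiens) for inhibition, read by CCK-8 assay, with a stated time of 48 h (on this read-out higher numbers stand for weaker inhibition and lower numbers for stronger inhibition), compound 2 (`O=C(NCCNS(=O)(=O)c1ccc(-c2ccccc2Oc2ccc(O)c(O)c2)s1)Nc1cc(Cl)cc(Cl)c1`) gives 4500 nM while compound 1 (`Cc1ccc(-c2ccsc2S(=O)(=O)NCCNC(=O)Nc2cc(C(F)(F)F)cc(C(F)(F)F)c2)c(Oc2ccc(O)c(O)c2)c1`) gives 5600 nM and compound 3 (`COc1ccc(NC(=S)NCCNS(=O)(=O)c2sccc2-c2ccc(C)cc2Oc2ccc(O)c(O)c2)cc1`) gives 8300 nM as its result. These three numbers lie within the usual scatter of one another, so compound 2 stands level with the other two and no ranking can be drawn from them. All three carry a 3,4-dihydroxyphenyl on an oxygen.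

Compound 4 (`O=C(NCCNS(=O)(=O)c1ccc(-c2ccccc2O[C@H]2CC[C@H](O)CC2)s1)Nc1cc(Cl)cc(Cl)c1`) keeps the rest of compound 2 and alters that one group. The difference is 4-hydroxycyclohexyl in place of 3,4-dihydroxyphenyl on an oxygen on an aromatic ring and it means that 4-hydroxycyclohexyl takes the place of 3,4-dihydroxyphenyl on an oxygen on an aromatic ring. An aromatic ring of carbon thus gives way to a non-aromatic one.

Among the measured compounds shown here, no measured pair shows this swap alone, since every tested compound keeps the group that leaves, so the forecast is uncertain. A modest weakening, meaning a somewhat higher number, is expected, and a result within the scatter would be no surprise. The estimated size of the change is a 2.0-fold higher number from compound 2 to compound 4 (0.30 log units; within the scatter) on this scale. In this assay the estimate for compound 4 is 9000 nM with an expected range from 3000 nM to 27000 nM around it.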

Compound 4, half-maximal inhibitory concentration: 14100 nM
Estimate against measurement, compound 4: 1.6-fold (0.19 log units) below, and the stated range covers the measured number.
By their numbers in this assay, from the lowest: compounds 2, 1, 3 and 4 (each within the scatter of the next, the first and the last beyond it).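

In this assay, among the compounds shown here, the step of a 3.1-fold higher number from compound 2 to compound 4 (0.50 log units; beyond the scatter) shows that this position responds to the group it carries, something the earlier compounds could not reveal because all of them keep 3,4-dihydroxyphenyl. The 3,4-dihydroxyphenyl group is not essential for a measurable result, since compound 4 still gives 14100 nM in this assay, although the step does mark a real weakening. The swap changes several things at once, replacing an aromatic ring with a non-aromatic one and bringing fewer hydrogen-bond donors and acceptors plus two defined stereocentres, and no available evidence ties the step to any one of these differences.

From the compounds shown here alone, it remains open which of these differences matters, and a 4-hydroxyphenyl group on the same oxygen would keep the aromatic ring with a single hydroxyl, while a 4-aminocyclohexyl group would keep the non-aromatic ring and replace that hydroxyl with an amine. It is also unknown whether the same swap would have a similar effect on compound 1 or compound 3, whose other parts differ from those of compound 2.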